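This account rests on a few compounds, and the source may have more. Where it says the series, first, only, none or still open, it means among the compounds named here.

Of the compounds shown here, three sharing one core have been measured in a functional assay on C6 cells (Rattus norvegicus) for cytotoxicity, read by MTT assay, with a stated time of 24 h, tested at 200 ug/mL; a higher number here means a weaker effect of the compound at the concentration tested, a lower number a stronger effect. Compound 2 `O=C(CSc1nnnn1-c1ccccc1)N/N=c1/scc(-c2ccccc2)n1-c1ccccc1` gives 22.6% in this assay. Compound 1 `Cn1nnnc1SCC(=O)N/N=c1/scc(-c2ccccc2)n1-c1ccccc1` gives 26.8%, and the step of a number 4.2 percentage points lower from compound 1 to compound 2 (within the scatter) shows that the two lie within the scatter of each other. Compound 3 `Cc1nnc(SCC(=O)N/N=c2/scc(-c3ccccc3)n2-c2ccccc2)s1` gives 59.2%, and the step of a number 36.6 percentage points higher from compound 2 to compound 3 (beyond the scatter) is large, as is the step of a number 32.4 percentage points higher from compound 1 to compound 3 (beyond the scatter). Compound 2 therefore stands together with compound 1, clearly apart from compound 3.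

Compound 4 `N#Cc1ccc(-c2cs/c(=N/NC(=O)CSc3nnnn3-c3ccccc3)n2-c2ccccc2)cc1` differs from compound 2 by cyano in place of hydrogen on an aromatic carbon. Going by the values given here, no measured step touches this part of the molecule: every measured step exchanges the group on the sulfur, and each compound carries the same phenyl groups. Nothing in the measured steps points in either direction for this change, so no step beyond the scatter is expected. For compound 4 the estimate is 25%, with a range from 10% to 45%, which means an expected step of a number 2.4 percentage points higher from compound 2 to compound 4 (within the scatter).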

Compound 4, a percentage reported as activity, at one concentration (the size of the read-out at that concentration, not a potency): 54%
The estimate for compound 4 lay 29 percentage points below the measured number; the whole stated range lies below it.
By their numbers in this assay, from the lowest: compounds 2 and 1 (each within the scatter of the next); then compounds 4 and 3 (each within the scatter of the next).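

Going by these compounds alone, the ring position that no earlier step touched turns out to matter: in this assay, going from phenyl to 4-cyanophenyl gives a number 31.4 percentage points higher from compound 2 to compound 4 (beyond the scatter), so adding a nitrile para to a large group leaves a clearly weaker effect at the tested concentration. Until now, only exchanging the group on the sulfur had produced a large step, so the far end of the molecule can no longer be treated as a part that changes little. No measurement shown here bears on what lies behind this step.

The compounds shown leave open whether a different group in the same place, such as an amine or a carboxylic acid, would shift the number as far. They also leave open whether the same cyano change would give a similar step with the groups on the sulfur of compound 1 or compound 3.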